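Difluorination of the benzamide in a pyrazole carboxamide series

A few compounds are considered here, and "the series" means these few. Any claim that something is new, unique, unknown or untested is made for them only; others in the source may bear on it.

Within the data shown here, compound 1 `Nc1ccccc1NC(=O)c1ccc(CNC(=O)c2n[nH]cc2NC(=O)c2ccccc2)cc1` stands lowest of the three numbers so far in a functional assay on A-375 cells (Homo sapiens) for inhibition, read by CCK-8 assay, with a stated time of 72 h (a lower number here means a stronger inhibitor, a higher number a weaker inhibitor), where compound 1 gives 1590 nM. Its nearest neighbour is compound 3 `Nc1ccccc1NC(=O)c1ccc(CNC(=O)c2n[nH]cc2NC(=O)c2ccccc2Cl)cc1`, which in this assay gives 2110 nM; the step of a 1.3-fold higher number from compound 1 to compound 3 (0.12 log units; within the scatter) is within the scatter. Among the measured compounds shown here, compound 2 `O=C(NO)c1ccc(CNC(=O)c2n[nH]cc2NC(=O)c2ccccc2F)cc1`, carrying a different head group and a single fluorine on the benzoyl ring, gives 3010 nM in this assay; no single-change step to compound 1 exists, and its two values with compound 1 differ by less than the scatter.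

Compound 4 `Nc1ccccc1NC(=O)c1ccc(CNC(=O)c2n[nH]cc2NC(=O)c2c(F)cccc2F)cc1` has not yet been measured. It differs from compound 1 as follows: 2,6-difluorophenyl in place of phenyl on a carbonyl carbon. For the measured compounds named here, the only step that bears on it is the one from compound 1 to compound 3, a halogen added to the benzoyl ring at the same carbonyl-bound position, and that step stayed within the scatter. A change of similar size or none beyond the scatter is therefore expected in this assay, the step of a 1.3-fold higher number from compound 1 to compound 4 (0.10 log units; within the scatter) being the expected outcome. Compound 4 is estimated at 2000 nM, with a range from 900 nM to 4500 nM.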

Compound 4, half-maximal inhibitory concentration: 1700 nM
Beside the measured number, compound 4's estimate is 1.2-fold (0.07 log units) above it, and the stated range covers the measured number.
By their numbers in this assay, from the lowest: compounds 1, 4, 3 and 2 (each within the scatter of the next).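

In this assay, a 1.1-fold higher number from compound 1 to compound 4 (0.03 log units; within the scatter) shows that two fluorines on the phenyl ring on this carbonyl carbon leave the number within the scatter, which a single chloro step could not show. Among these compounds, with a 1.2-fold lower number from compound 3 to compound 4 (0.09 log units; within the scatter) also within the scatter, phenyl, 2-chlorophenyl and 2,6-difluorophenyl cannot be told apart at this place when the head group of compound 1 is kept, and no compound with that head group goes against this. No data at hand speak to why these changes leave the number within the scatter.

From the compounds shown here alone, whether an amine, a carboxylic acid or a longer chain on this ring would move the number beyond the scatter remains open. Going by these compounds, the effect of the head group also remains open, as compound 2 differs from the others in more than one place.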